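Changing the ester group from compound 2 to compound 4

The source may report more compounds than this note shows. Statements on the series, on what has been measured and on what is new or still open speak of the compounds shown alone.

Among the compounds with values here, in an ADME assay on L6 cells (Rattus norvegicus) for cytotoxicity, read by resazurin assay, with a stated time of 70 h (a lower number here means a stronger inhibitor, a higher number a weaker inhibitor), compound 2 `COc1cc(OC)cc(C(=O)Oc2ccc3c(c2)C(C)=CC(C)(C)N3Cc2ccccc2)c1` gives 24000 nM and stands level with compound 1 `CC(=O)Oc1ccc2c(c1)C(C)=CC(C)(C)N2Cc1ccccc1` at 24000 nM on the numbers so far. Compound 3 `COc1cc(OC)cc(C(=O)Oc2ccc3c(c2)C(C)=CC(C)(C)N3Cc2ccc(C)cc2)c1` returns only a limit of the assay (> 200000 nM), not a number.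

Compound 4 `CC1=CC(C)(C)N(Cc2ccccc2)c2ccc(OC(=O)C(C)(C)C)cc21` carries tert-butyl in place of 3,5-dimethoxyphenyl on a carbonyl carbon. Within the data shown here, the closest precedent is the change at that same carbonyl carbon, where 3,5-dimethoxyphenyl replaced methyl and the result was no change at the digits printed from compound 1 to compound 2 (within the scatter) as the measured step. The other measured step, with methyl in place of hydrogen on an aromatic carbon, was an at least 8.3-fold higher number from compound 2 to compound 3 (0.92 log units; beyond the scatter) and lies at a different place, so it carries little weight here.

No step beyond the scatter is therefore expected in this assay and no direction is favoured. The expected step is no change at the digits printed from compound 2 to compound 4 (within the scatter) in this assay. For compound 4 the estimated value is 24000 nM within an expected range of 9000 nM to 65000 nM.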

Compound 4, half-maximal inhibitory concentration: 170000 nM
For compound 4 the middle estimate is 7.1-fold (0.85 log units) below the measured one; measured number outside the range, above it.
By their numbers in this assay, from the lowest: compounds 1 and 2 (each within the scatter of the next); then compound 4. At a limit, above all of these: compound 3.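

The group on the carbonyl carbon can move the read-out in this assay after all: tert-butyl gives a 7.1-fold higher number from compound 2 to compound 4 (0.85 log units; beyond the scatter), and the same group set against methyl gives a 7.1-fold higher number from compound 1 to compound 4 (0.85 log units; beyond the scatter). The read-out does not simply follow ring versus no ring, since methyl and tert-butyl both lack a ring, yet compound 1 stays level with compound 2 while compound 4 departs from both. Compound 3 remains a limit and not a number, so its order against compound 4 rests on that limit alone: the limit of > 200000 nM in this assay, at which 1 of the 4 values shown sits.

The compounds shown leave open whether the higher number is particular to tert-butyl or would also come with isopropyl or a longer straight chain on the carbonyl carbon. They also leave open how the methyl on an aromatic carbon that separates compound 3 from compound 2 would act alongside tert-butyl.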